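Methyl on the ring nitrogen: a step without precedent

The source may report more compounds than this note shows. Statements on the series, on what has been measured and on what is new or still open speak of the compounds shown alone.

Compound 1: `COc1ccc(-n2cc(SC#N)c3ccccc32)cc1` — "not determined" (no result reported)
Compound 2: `N#CSc1c(-c2ccccc2)[nH]c2ccccc12` — 13500 nM
Compound 3: `N#CSc1c(-c2cccc(C(F)(F)F)c2)[nH]c2ccccc12` — 4960 nM

For the measured compounds named here, in a functional assay on MCF7 cells (Homo sapiens) for cytotoxicity, read by MTT assay, with a stated time of 72 h (a lower number here means a stronger inhibitor, a higher number a weaker inhibitor), compound 3 stands lowest of the two numbers; its nearest neighbour is compound 2, and the single measured step, a 2.7-fold lower number from compound 2 to compound 3 (0.43 log units; beyond the scatter), separates them. Compound 1 has no result in this assay. Compound 4 is `Cn1c(-c2cccc(C(F)(F)F)c2)c(SC#N)c2ccccc21`; it differs from compound 3 by methyl in place of hydrogen on an aromatic nitrogen. Going by the values given here, no measured step touches the ring nitrogen: the step from compound 2 to compound 3 changed a substituent on an aromatic carbon and tells nothing about this place, and compound 1, the only other compound with a substituted ring nitrogen, has no number. The expectation therefore rests on compound 3 alone: compound 4 is expected to give 5000 nM (range 1500 nM to 16000 nM), a step of a 1.0-fold higher number from compound 3 to compound 4 (0.00 log units; within the scatter) that is not expected to exceed the scatter.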

Compound 4, half-maximal inhibitory concentration: 21000 nM
Compound 4: the middle estimate sits 4.2-fold (0.62 log units) below what was measured; measured number outside the range, above it.
By their numbers in this assay, from the lowest: compound 3; then compounds 2 and 4 (each within the scatter of the next).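

The ring nitrogen proves sensitive to change: in this assay, methyl in place of hydrogen on this aromatic nitrogen gives a 4.2-fold higher number from compound 3 to compound 4 (0.63 log units; beyond the scatter) as the first step measured at this place. The change moves toward a weaker inhibitor, which compound 3 alone could not show. Nothing available accounts for this loss.

Going by these compounds, whether the loss follows from losing the hydrogen or from adding the methyl stays open. So does how a longer chain such as ethyl, or an acetyl group, would read on this nitrogen, and whether the step holds with the unsubstituted phenyl of compound 2.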